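The compounds below may be only part of what the source reports. "The series", "measured", "known", "first", "only" and "open" are said of these compounds alone.

The compounds here were tested in a functional assay on M21 cells (Homo sapiens) for antiproliferative activity, read by sulforhodamine B assay, with a stated time of 48 h; on this read-out lower numbers stand for stronger inhibition of growth and higher numbers for weaker inhibition of growth. Compound 1, `NS(=O)(=O)NCC1CCN(c2cc(-c3cccc(Cl)c3)ncn2)CC1`, gives 62500 nM in this assay. Compound 3, `NS(=O)(=O)NCCC1CCN(c2cc(-c3cccc(Cl)c3)ncn2)CC1`, shares its core but differs from compound 1 by (sulfamoylamino)methyl in place of sulfamoylamino on a saturated chain carbon bound to a saturated ring carbon; in this assay compound 3 gives 50700 nM, which amounts to a 1.2-fold lower number from compound 1 to compound 3 (0.09 log units; within the scatter). Compound 2, `COc1ccccc1-c1cc(N2CCC(CNS(N)(=O)=O)CC2)ncn1`, differs from compound 1 by 2-methoxyphenyl in place of 3-chlorophenyl on an aromatic carbon. In this assay compound 2 reaches only the limit > 100000 nM, so no number is known for it; that value is the limit of > 100000 nM in this assay, at which 1 of the 3 values shown sits. The change from compound 1 to compound 2 therefore made an at least 1.6-fold higher number from compound 1 to compound 2 (0.20 log units; that floor lies within the scatter).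

Compound 4, `COc1ccccc1-c1cc(N2CCC(CCNS(N)(=O)=O)CC2)ncn1`, has not yet been measured. It differs from compound 3 by 2-methoxyphenyl in place of 3-chlorophenyl on an aromatic carbon, the same change that was made from compound 1 to compound 2, and the place of the change is described in the same words in both cases. The two cores on which the change is made differ by (sulfamoylamino)methyl in place of sulfamoylamino on a saturated chain carbon bound to a saturated ring carbon. Since the earlier change gave an at least 1.6-fold higher number from compound 1 to compound 2 (0.20 log units; that floor lies within the scatter), the step from compound 3 to compound 4 is expected to be of a similar size, a 2.0-fold higher number from compound 3 to compound 4 (0.29 log units; within the scatter). Compound 4 is thus expected to give about 100000 nM in this assay, with the expected range running from 50000 nM to 250000 nM, and with a real chance that this assay returns only a limit for it.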

Compound 4, concentration for 50% growth inhibition: 96900 nM
Estimate against measurement, compound 4: 1.0-fold (0.01 log units) above; low and high end bracket the measured number.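

On the core of compound 3, putting 2-methoxyphenyl in place of 3-chlorophenyl gives a 1.9-fold higher number from compound 3 to compound 4 (0.28 log units; within the scatter) in this assay, so this step on its own does not show that the change alters growth inhibition. Set beside the same change on the core of compound 1, the result fits a change that carries over from one core to the other, but it cannot establish that the two steps match: the same change on two cores in this assay, an at least 1.6-fold higher number (0.20 log units; that floor lies within the scatter) from compound 1 to compound 2 and a 1.9-fold higher number (0.28 log units; within the scatter) from compound 3 to compound 4; the limit leaves it open whether they differ. In this assay compound 2 gives > 100000 nM, which is a limit of the assay and not a number. Putting (sulfamoylamino)methyl in place of sulfamoylamino gives an at least 1.0-fold lower number from compound 2 to compound 4 (0.01 log units; that floor lies within the scatter) in this assay, and this floor cannot establish that the step matches the same change on the core of compound 1: the same change on two cores in this assay, a 1.2-fold lower number (0.09 log units; within the scatter) from compound 1 to compound 3 and an at least 1.0-fold lower number (0.01 log units; that floor lies within the scatter) from compound 2 to compound 4; the limit leaves it open whether they differ.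

The compounds shown cover only two aryl groups and two chain lengths, which leaves open whether any other group on this aromatic carbon, such as a phenyl ring bearing an amine or a carboxylic acid, would give a step beyond the scatter. They also leave open how a longer chain, or a carboxylic acid in place of the sulfamoylamino end, would read in this assay.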